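This account rests on a few compounds, and the source may have more. Where it says the series, first, only, none or still open, it means among the compounds named here.

Measured compounds:
Compound 1, `CCS(=O)(=O)Nc1cc(-c2ccc3ncnc(Nc4ccc(F)cc4)c3c2)cnc1OC`: in a functional assay on SNU-638 cells (Homo sapiens) for cytotoxicity, read by sulforhodamine B assay, with a stated time of 72 h (on this read-out higher numbers stand for weaker inhibition and lower numbers for stronger inhibition), compound 1 gives 2400 nM.
Compound 2, `CCS(=O)(=O)Nc1cc(-c2ccc3ncnc(Nc4ccc(OC)c(Cl)c4)c3c2)cnc1OC`: in this assay compound 2 gives 3620 nM.
Compound 3, `CCS(=O)(=O)Nc1cc(-c2ccc3ncnc(Nc4cccc(C(=O)OC)c4)c3c2)cnc1OC`: in this assay compound 3 gives 1120 nM.

Among these three numbers compound 1 holds the second highest; compound 2 lies close to it, and compound 3 is the furthest away, with the lowest number of the set. Compound 4, `CCS(=O)(=O)Nc1cc(-c2ccc3ncnc(Nc4ccc(F)c(C(=O)OC)c4)c3c2)cnc1OC`, has not yet been measured. It differs from compound 1 in one spot: methoxycarbonyl in place of hydrogen on an aromatic carbon. Among the measured compounds shown here, two measured steps bear on this change. The step of a 2.1-fold lower number from compound 1 to compound 3 (0.33 log units; beyond the scatter) brought in the same methoxycarbonyl group, though there the fluoro group was given up at the same time, and the step of a 3.2-fold lower number from compound 2 to compound 3 (0.51 log units; beyond the scatter) points the same way, while a 1.5-fold higher number from compound 1 to compound 2 (0.18 log units; within the scatter) stayed within the scatter. Compound 4 keeps the fluoro group of compound 1 and also carries the methoxycarbonyl group of compound 3. For the measured compounds named here, a modest fall in the number, close to the size of the earlier steps, is expected for compound 4: a 1.7-fold lower number from compound 1 to compound 4 (0.23 log units; within the scatter). The estimate for compound 4 in this assay is 1400 nM, with a range from 600 nM to 3200 nM.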

Compound 4, half-maximal inhibitory concentration: 2540 nM
Estimate against measurement, compound 4: 1.8-fold (0.26 log units) below; the range from low to high includes it.
By their numbers in this assay, from the lowest: compound 3; then compounds 1, 4 and 2 (each within the scatter of the next).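

In this assay, methoxycarbonyl in place of hydrogen on the 4-fluorophenyl ring leaves the number unchanged within the scatter (a 1.1-fold higher number from compound 1 to compound 4 (0.02 log units; within the scatter)), so the lower number of compound 3 does not carry over to a ring that also holds a fluoro group. The fluoro group itself makes a readable difference once methoxycarbonyl is present, though only a modest one (a 2.3-fold higher number from compound 3 to compound 4 (0.36 log units; beyond the scatter)), while the other listed swap of the whole ring stays within the scatter (a 1.4-fold lower number from compound 2 to compound 4 (0.15 log units; within the scatter)). Nothing measured here explains why methoxycarbonyl reads differently with and without the fluoro group.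

Open, as far as these compounds go, is how a carboxylic acid or a primary amide would read on this same aromatic carbon in place of methoxycarbonyl. Also open, from the compounds shown here alone, is whether chloro or methyl, set where the fluoro group sits, would give a number like that of compound 3 or that of compound 4.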